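The compounds below may be only part of what the source reports. "The series", "measured", "known", "first", "only" and "open" are said of these compounds alone.

Among the compounds with values here, compound 1 `CC(=O)Nc1nc(-c2cccc(NS(=O)(=O)c3ccc(Br)cc3)c2)cs1` is the only member of the series that gives a number rather than a limit in a functional assay on A-375 cells (Homo sapiens) for antiproliferative activity, read by trypan blue exclusion, with a stated time of 48 h, tested at 10 uM (a lower number here means a stronger effect, a higher number a weaker effect of the compound at the concentration tested), where compound 1 gives 25.6%. Compound 2 `CC(=O)Nc1nc(-c2cccc(NS(=O)(=O)c3ccc(C#C[Si](C)(C)C)cc3)c2)cs1` stands at the limit of the assay in this assay, giving < 1%. Compound 3 `CCCCCCCCC#Cc1ccc(S(=O)(=O)Nc2cccc(-c3csc(NC(C)=O)n3)c2)cc1` likewise reaches only the limit of the assay, giving < 1%, so its standing is known merely as a bound, not as a number. Both measured moves away from compound 1 are large: a number at least 24.6 percentage points lower from compound 1 to compound 2 (beyond the scatter) and a number at least 24.6 percentage points lower from compound 1 to compound 3 (beyond the scatter). The move between the two limit values, a step that the two limits leave unreadable from compound 2 to compound 3, cannot be sized, because both sit at the limit of < 1% in this assay, at which 2 of the 3 values shown sit.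

Compound 4 `CC(=O)Nc1nc(-c2cccc(NS(=O)(=O)c3ccc(C#CCCc4ccccc4)cc3)c2)cs1` differs from compound 3 only on the saturated part of the chain beyond the triple bond: phenyl in place of hexyl on a saturated chain carbon, two bonds along the chain from a triple-bonded carbon. Within the data shown here, no measured step alters a group at this place; the steps that bear on the region are those that replace bromo with an alkynyl group, and both carried the value to the limit, while the one step that changes the chain itself is unreadable. The expected step is therefore none beyond the scatter, estimated as a number at least 2 percentage points higher from compound 3 to compound 4 (that floor lies within the scatter). For compound 4 the expected value in this assay is 3%, with a range from 0% to 15%, and most likely it will again be reported only as the limit.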

Compound 4, a percentage reported as activity, at one concentration (the size of the read-out at that concentration, not a potency): < 1%
Compound 4 ended at the assay's limit (the forecaster's own chance of this, stated with the estimate: 70%); middle value at least 2 percentage points from the limit.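

With 4-phenylbut-1-yn-1-yl in place of bromo on the aromatic carbon, the third alkynyl group shows a number at least 24.6 percentage points lower from compound 1 to compound 4 (beyond the scatter), so an aromatic ring at the chain end, with phenyl in place of hexyl, does not take the series back towards compound 1. Compound 4 gives < 1% in this assay, which is a limit of the assay and not a number. The chain end beyond the triple bond now carries a silicon-bearing group in compound 2, hexyl in compound 3 and phenyl in compound 4, and no step among these three can be read: the limit of < 1% in this assay, at which 3 of the 4 values shown sit.

Going by these compounds, the order of compound 2, compound 3 and compound 4 remains open, as does how much of the change from compound 1 belongs to the triple bond itself rather than to the chain it carries. Also open, on these data alone, is whether an amine or a carboxylic acid at the end of the chain, or a shorter chain such as a bare ethynyl group, would keep the value at the limit or lift it to a readable number.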